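Chain Lengthening in an Aryl Ether Ketone Series

The compounds below may be only part of what the source reports. "The series", "measured", "known", "first", "only" and "open" are said of these compounds alone.

Compound 1 `CCCCOc1cc(OC)c(Br)cc1C(C)=O`, compound 2 `CCCCCCOc1cc(OC)c(Br)cc1C(C)=O` and compound 3 `CCCCCCCCCCCCCCOc1cc(OC)ccc1C(C)=O` were tested in a functional assay, with stated times of 30 s and 6 min, in the presence of a further agent that is not named here; on this read-out lower numbers stand for stronger inhibition and higher numbers for weaker inhibition. In this assay compound 1 gives 38200000 nM. In this assay compound 2 gives 34000000 nM, and compound 3 gives 35900000 nM in this assay. The three numbers lie within the scatter of one another, so no order among them is claimed. Compound 2 arises from compound 1 by ethyl in place of hydrogen on a saturated chain carbon, four bonds along the chain from an oxygen on an aromatic ring, a change that made a 1.1-fold lower number from compound 1 to compound 2 (0.05 log units; within the scatter). Compound 4 `CCCCCCCCCCCCCCCCOc1cc(OC)ccc1C(C)=O` has not yet been measured. It arises from compound 3 by ethyl in place of hydrogen on a saturated chain carbon, ten or more bonds along the chain from an oxygen on an aromatic ring. This is the same kind of change as that from compound 1 to compound 2, but the place on the chain differs, as the two descriptions of the changes show: the carbon in the new pair lies further along the chain from the oxygen on the aromatic ring than in the earlier pair. How the core of compound 3 differs from that of compound 1 is not broken down here. Compound 4 is expected to show a step of a 1.0-fold higher number from compound 3 to compound 4 (0.00 log units; within the scatter) in this assay because the step of a 1.1-fold lower number from compound 1 to compound 2 (0.05 log units; within the scatter) stayed within the scatter. The estimate for compound 4 in this assay is 36000000 nM, with a range from 15000000 nM to 85000000 nM.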

Compound 4, half-maximal inhibitory concentration: 39400000 nM
The estimate for compound 4 lay 1.1-fold (0.04 log units) below the measured number, and the stated range covers the measured number.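

In this assay the replacement of hydrogen by ethyl on the long chain gives a 1.1-fold higher number from compound 3 to compound 4 (0.04 log units; within the scatter). Set beside the earlier step, the same change reads alike on the two cores: the same change on two cores in this assay, a 1.1-fold lower number (0.05 log units; within the scatter) from compound 1 to compound 2 and a 1.1-fold higher number (0.04 log units; within the scatter) from compound 3 to compound 4, 1.2-fold (0.09 log units) apart, within the scatter of two such steps This shows that in these two pairs the change moved the number by no more than the scatter, both on the shorter chain and at the far place on the longer one, but it does not show that the change would behave this way on any other core in the series, and with the core and the place on the chain differing together, their contributions cannot be told apart.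

On these data alone, whether an amine or a carboxylic acid in place of the alkyl chain would move the number beyond the scatter remains open. It also remains open whether a shorter chain, such as ethyl, would read differently from the chains shown here.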